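This account rests on a few compounds, and the source may have more. Where it says the series, first, only, none or still open, it means among the compounds named here.

Series notes. In a functional assay on CAL1 cells for inhibition of chemerin-like receptor 1 (Homo sapiens), with a stated time of 45 min (on this read-out lower numbers stand for stronger inhibition and higher numbers for weaker inhibition), compound 2 `CCCCN(c1nc2c(C(=O)O)cccc2o1)[C@H](C)c1ccc(-c2ccccc2-c2nnn[nH]2)cc1` gives 17 nM, the highest of the three numbers recorded so far. Compound 3 `CCCCN(c1nc2c(NS(C)(=O)=O)cccc2o1)[C@H](C)c1ccc(-c2ccccc2-c2nnn[nH]2)cc1` gives 14 nM in this assay. For the measured compounds named here, compound 1 `C[C@H](c1ccc(-c2cc(Cl)ccc2-c2nc(=O)o[nH]2)cc1)N(CC1CC1)c1nc2c(C(=O)O)cccc2o1` gives 1.3 nM in this assay, the lowest of the three, but compound 1 differs from compound 2 in more than one place, so that pair yields no single step. Going by the values given here, the one single-place step measured is a 1.2-fold lower number from compound 2 to compound 3 (0.08 log units; within the scatter).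

Compound 4 `CCCCN(c1nc2c(C(=O)NS(C)(=O)=O)cccc2o1)[C@H](C)c1ccc(-c2ccccc2-c2nnn[nH]2)cc1` differs from compound 2 by methanesulfonamido in place of hydroxy on a carbonyl carbon. Among the compounds with values here, the only measured step that bears on this change is the one from compound 2 to compound 3, in which the carboxy group itself was replaced on the aromatic carbon, and that step stayed within the scatter. Nothing in this set shows a move beyond the scatter when the group on that aromatic carbon is altered, so the expected step is a 1.1-fold lower number from compound 2 to compound 4 (0.05 log units; within the scatter), that is, none beyond the scatter. For compound 4 the estimate in this assay is 15 nM, with a range of 6 nM to 40 nM.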

Compound 4, half-maximal inhibitory concentration: 14 nM
Beside the measured number, compound 4's estimate is 1.1-fold (0.03 log units) above it, within the range that was stated.
By their numbers in this assay, from the lowest: compound 1; then compounds 3, 4 and 2 (each within the scatter of the next).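

In this assay the swap of hydroxy for methanesulfonamido on the carbonyl carbon gives a 1.2-fold lower number from compound 2 to compound 4 (0.08 log units; within the scatter) and, read against the group set directly on the aromatic carbon, (methylsulfonyl)carbamoyl in place of methanesulfonamido gives no change at the digits printed from compound 3 to compound 4 (within the scatter) as its step. Carboxy, methanesulfonamido and (methylsulfonyl)carbamoyl therefore cannot be told apart on this read-out in compound 2, compound 3 and compound 4, so the larger group with its extra carbonyl shows no separation from either smaller one. No measurement at hand offers an explanation for this flat result.

Open, as far as these compounds go, is whether a primary amine or a methyl ester on that aromatic carbon would stay within the scatter of these three groups. Also open, from the compounds shown here alone, is whether carboxy to (methylsulfonyl)carbamoyl would read the same on the core of compound 1.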